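A few compounds are considered here, and "the series" means these few. Any claim that something is new, unique, unknown or untested is made for them only; others in the source may bear on it.

Measured compounds in a functional assay on the whole organism (strain CD-1) with Mus musculus as the target, in the maximal electroshock model, with a stated time of 2 h; a higher number here means that more compound is needed for the effect, a lower number that less compound is needed:
- compound 1 `CC1(c2ccccc2)CC(=O)N(CC(=O)N2CCOCC2)C1=O`: 300 mg/kg
- compound 2 `CC1(c2ccccc2)CC(=O)N(CC(=O)N2CCN(c3ccc(Cl)cc3)CC2)C1=O`: "not active" (no number reported)
- compound 3 `CC1(c2ccccc2)CC(=O)N(CC(=O)N2CCN(c3ccccc3F)CC2)C1=O`: "not active" (no number reported)

Compound 3 stands without a number in this assay; the same holds for compound 2, so only compound 1 gives a figure. Among the compounds with values here, no step between measured compounds is recorded, and the two results without a number allow no ordering among the three.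

Compound 4 `CC1(c2ccccc2)CC(=O)N(CC(=O)N2CCN(c3ccc(Cl)c(Cl)c3)CC2)C1=O` differs from compound 3 in one place: 3,4-dichlorophenyl in place of 2-fluorophenyl on an amine nitrogen in a ring

Within the data shown here, with no recorded step to lean on, no change in this assay beyond the usual scatter is expected from this exchange; compound 4 is expected to behave like compound 3 and compound 2, most likely again without a reported number. Should a figure appear, compound 4 is estimated at 300 mg/kg, within 100 mg/kg to 1000 mg/kg.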

Compound 4, minimum effective dose: 300 mg/kg
Compound 4: middle estimate and measured number agree at the digits printed; the range from low to high includes it.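

In this assay, within the data shown here, compound 3 has no number, so no step to compound 4 can be read. The compounds shown leave open how 3,4-dichlorophenyl and 2-fluorophenyl compare on the ring nitrogen. No supporting data bear on this result.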